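Swapping the Sulfonyl Aryl Group: Mouse Microsomal Stability

The source may hold more compounds than are shown below. What is called first, only, known or untested is meant among the compounds shown, and "the series" means these compounds.

Compound 1 `O=C(NCc1ccc(S(=O)(=O)c2ccc(F)c(F)c2)cc1)c1cc2cnccc2[nH]1`: 58%
Compound 2 `O=C(NCc1ccc(S(=O)(=O)N2CCCCC2)cc1)c1cc2ccncc2[nH]1`: "below limit of detection" (no number reported)
Compound 3 `O=C(NCc1ccc(S(=O)(=O)c2ccccc2)cc1)c1ccc2nncn2c1`: 47%

These compounds were tested in an ADME assay on microsomes from liver (Mus musculus) for metabolic stability, read by LC-MS, with a stated time of 30 min, tested at 1 uM; a lower number here means that less of the compound is left, a higher number that more of the compound is left. Compound 1 gives 58% and stands highest of the two numbers; compound 3 gives 47%, a number lower by a margin beyond the usual scatter. For compound 2 the reading is "below limit of detection" (no number reported), an entry for which no single number is reported.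

Compound 4 `Cc1ccccc1S(=O)(=O)c1ccc(CNC(=O)c2cc3cnccc3[nH]2)cc1` has not yet been measured. It differs from compound 1 at one place: 2-methylphenyl in place of 3,4-difluorophenyl on a sulfonyl sulfur. Among the compounds with values here, no pair of measured compounds shows this same change, so nothing measured tells its size directly. The step of a number 13 percentage points lower from compound 1 to compound 4 (beyond the scatter) is expected to be downward, of a size close to the usual scatter. Compound 4 is therefore estimated at 45%, with a range from 25% to 65%.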

Compound 4, percent of the compound remaining: 15%
Compound 4: the middle estimate sits 30 percentage points above what was measured; measured number outside the range, below it.
By their numbers in this assay, from the lowest: compound 4; then compound 3; then compound 1.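

In this assay, the group on the sulfonyl sulfur proves to matter a great deal: 2-methylphenyl in place of 3,4-difluorophenyl gives a number 43 percentage points lower from compound 1 to compound 4 (beyond the scatter) and counts as a large step. Both groups are a single six-membered aromatic ring of carbon only, with no hydrogen-bond donors or acceptors, so these counts do not predict the change. Nothing measured here bears on what lies behind it.

The compounds shown leave open whether the loss of the two fluorines or the gain of the methyl drives the step. Also open, on these data alone, is how plain phenyl or methoxyphenyl on the sulfonyl sulfur would read with the core of compound 1.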